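The compounds below may be only part of what the source reports. "The series", "measured", "known", "first", "only" and "open" are said of these compounds alone.

Compound 1 `CCCc1n[nH]c2c(=O)n(NC(=O)c3ccccc3)c(-c3cccc(OC)c3)nc12` gives 23.6% in a functional assay on DU-145 cells (Homo sapiens) for cytotoxicity, read by sulforhodamine B assay, with a stated time of 2 days, tested at 100 uM; on this read-out lower numbers stand for less inhibition and higher numbers for more inhibition at the one concentration tested (going by the name of the read-out). Compound 2 `COc1cccc(-c2nc3c(-c4cccc(Cl)c4)n[nH]c3c(=O)n2NC(=O)c2ccccc2)c1` gives 93.5% in this assay.

Compound 2 stands highest of the two numbers; its nearest neighbour is compound 1, well beyond the scatter. Among the measured compounds shown here, the single measured step, a number 69.9 percentage points higher from compound 1 to compound 2 (beyond the scatter), bears on the change to compound 3 `COc1cccc(-c2nc3c(-c4ccco4)n[nH]c3c(=O)n2NC(=O)c2ccccc2)c1`: furan-2-yl in place of 3-chlorophenyl on an aromatic carbon. That step was large. Since furan-2-yl, like 3-chlorophenyl, brings one aromatic ring, whereas propyl brought none, compound 3 is expected to land between the two measured values, a downward step a number 33.5 percentage points lower from compound 2 to compound 3 (beyond the scatter). Compound 3 is estimated at 60%, in the range 30% to 90%.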

Compound 3, a percentage reported as inhibition, at one concentration (the size of the read-out at that concentration, not a potency): 50.5%
Compound 3: the middle estimate sits 9.5 percentage points above what was measured; the range from low to high includes it.
By their numbers in this assay, from the lowest: compound 1; then compound 3; then compound 2.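

In this assay an aromatic ring at this carbon does not alone settle the result, for furan-2-yl in place of 3-chlorophenyl gives up much of the gain (a number 43 percentage points lower from compound 2 to compound 3 (beyond the scatter)). Furan-2-yl still keeps part of that gain over propyl (a number 26.9 percentage points higher from compound 1 to compound 3 (beyond the scatter)), so these three groups fall into a clear order at this position. Nothing at hand explains that order.

The compounds shown leave open whether the chlorine or the six-membered ring goes with the higher number of compound 2, a question on which a plain phenyl would bear. From the compounds shown here alone, how an amine or a carboxylic acid at this carbon would read also remains open.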